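The source may report more compounds than this note shows. Statements on the series, on what has been measured and on what is new or still open speak of the compounds shown alone.

Measured compounds in an assay for inhibition of Polyunsaturated fatty acid 5-lipoxygenase (Rattus norvegicus); on this read-out higher numbers stand for weaker inhibition and lower numbers for stronger inhibition:
- compound 1 `CCCCC/C=C\C/C=C\C/C=C\C=C\C(CCCS)CCCC(=O)O` gives 36000 nM
- compound 2 `CCCCC/C=C\C/C=C\C/C=C\C=C\C(CCCC(=O)O)CC(=O)O` gives 96000 nM
- compound 3 `CCCCC/C=C\C/C=C\C/C=C\C=C\C(CCCC(=O)O)=N\O` gives 11000 nM

Compound 3 stands at the lowest number of the three in this assay; compound 1 is its nearest neighbour and compound 2 the furthest, both steps to it beyond the scatter. For the measured compounds named here, the one step measured between neighbouring compounds, a 2.7-fold higher number from compound 1 to compound 2 (0.43 log units; beyond the scatter), concerns a change on a saturated chain carbon, not at the position altered here.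

Compound 4 `CCCCC/C=C\C/C=C\C/C=C\C=C\C(CCCC(=O)O)=N\N=C(\N)S` differs from compound 3 by a group of 4 heavy atoms (1 carbon, 2 nitrogen, 1 sulfur; no ring) in place of one oxygen atom, on a double-bonded nitrogen. Going by the values given here, no measured step touches this double-bonded nitrogen, so the only direct guide is that compound 3 already gives the lowest number of the set and that small replacements elsewhere have moved the number modestly. A change of similar size is expected, a 1.8-fold lower number from compound 3 to compound 4 (0.26 log units; within the scatter), with the direction uncertain and leaning toward a somewhat lower number.

Compound 4 is therefore estimated at 6000 nM in this assay, within a range from 1500 nM to 25000 nM.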

Compound 4, half-maximal inhibitory concentration: 7900 nM
The estimate for compound 4 lay 1.3-fold (0.12 log units) below the measured number; low and high end bracket the measured number.
By their numbers in this assay, from the lowest: compounds 4 and 3 (each within the scatter of the next); then compound 1; then compound 2.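

For the compounds shown here, on the double-bonded nitrogen, hydroxy gives way to a group of 4 heavy atoms (1 carbon, 2 nitrogen, 1 sulfur; no ring), the first change at this position, and this assay shows a 1.4-fold lower number from compound 3 to compound 4 (0.14 log units; within the scatter). At this position, then, a group with three more heavy atoms than hydroxy leaves the read-out within the usual scatter, so the pair does not separate the two groups. Nothing available explains this outcome or links it to any property of either group.

Open questions remain at the same nitrogen: whether a methoxy group or an amino group would also stay within the scatter of compound 3, and whether a still longer chain would do so. The pair also leaves open whether the sulfur in compound 4 matters, which the same group carrying oxygen in its place could test.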